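A Triazole Substituent Swap on a Shared Core

A few compounds are considered here, and "the series" means these few. Any claim that something is new, unique, unknown or untested is made for them only; others in the source may bear on it.

Compound 1 `O=C1O/C(=C\Cn2cc(-c3ccc(Br)cc3)nn2)C(OCc2ccccc2)=C1OCc1ccccc1` reaches only the assay limit, > 100000 nM, in a functional assay on HepG2 cells (Homo sapiens) for antiproliferative activity, read by MTT assay, with a stated time of 72 h; a higher number here means a weaker inhibitor, a lower number a stronger inhibitor.
Compound 2 `COc1ccccc1-c1cn(C[C@H](O)[C@H]2OC(=O)C(OCc3ccccc3)=C2OCc2ccccc2)nn1` likewise sits at the assay limit, > 100000 nM, in this assay.
Compound 3 `O=C1O/C(=C\Cn2cc(-c3cc(C(F)(F)F)cc(C(F)(F)F)c3)nn2)C(OCc2ccccc2)=C1OCc1ccccc1` also shows only the assay limit, > 100000 nM, in this assay.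

Compound 2 therefore stands nowhere above its neighbours: every value so far is a limit rather than a number, as the limit of > 100000 nM in this assay, at which 3 of the 3 values shown sit, records, so no measured step and no ordering can be drawn among these three compounds.

Compound 4 `Cc1ccc(S(=O)(=O)NCc2cn(C[C@H](O)[C@H]3OC(=O)C(OCc4ccccc4)=C3OCc3ccccc3)nn2)cc1` is the next variation. It differs from compound 2 in one place: (((4-methylphenyl)sulfonyl)amino)methyl in place of 2-methoxyphenyl on an aromatic carbon.

Among the measured compounds shown here, with no measured step to lean on, the expected change from compound 2 to compound 4 is a number no higher from compound 2 to compound 4 (the limit leaves the size open), that is, none beyond the scatter, and most likely another limit. Compound 4 is thus estimated at 100000 nM, within the range 30000 nM to 300000 nM.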

Compound 4, half-maximal inhibitory concentration: 24900 nM
The estimate for compound 4 lay 4.0-fold (0.60 log units) above the measured number, outside the stated range (below it).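

Changing the group on this aromatic carbon gives the first readable shift in this assay: (((4-methylphenyl)sulfonyl)amino)methyl in place of 2-methoxyphenyl gives an at least 4.0-fold lower number from compound 2 to compound 4 (0.60 log units; beyond the scatter). The read-out therefore responds to what stands at this position, at least for this pair on the shared core. Going by these compounds, the true size of the step stays open, as compound 2 gives only a limit rather than a number: the limit of > 100000 nM in this assay, at which 3 of the 4 values shown sit.

The compounds shown do not tell whether the sulfonyl amino link or the 4-methylphenyl ring carries the change. A plain aminomethyl group or a carboxylic acid on this carbon would be one way to separate the two.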